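Cyclohexyl for 1H-imidazol-1-yl on the shared core

The compounds below may be only part of what the source reports. "The series", "measured", "known", "first", "only" and "open" are said of these compounds alone.

Within the data shown here, compound 1 (`O=C(/C=C/c1ccc([N+](=O)[O-])o1)c1ccc(Br)cc1`) and compound 2 (`O=C(/C=C/c1ccc([N+](=O)[O-])o1)c1ccc(-n2ccnc2)cc1`) are the two measured members. In a functional assay on U-87MG ATCC cells for inhibition, with U-87 MG (Homo sapiens) as the target, read by sulforhodamine B assay, with a stated time of 72 h (on this read-out higher numbers stand for an effect only at larger amounts of compound and lower numbers for an effect already at smaller amounts), compound 1 gives 12600 nM and compound 2 gives 13400 nM with no separation beyond the scatter, so compound 2 stands level with compound 1.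

The next step leads to compound 3 (`O=C(/C=C/c1ccc([N+](=O)[O-])o1)c1ccc(C2CCCCC2)cc1`), not yet measured, with cyclohexyl in place of 1H-imidazol-1-yl on an aromatic carbon, para to a large group (cyclohexyl in place of 1H-imidazol-1-yl on an aromatic carbon). Among the measured compounds shown here, one measured step bears on this change: 1H-imidazol-1-yl in place of bromo on an aromatic carbon, which gave a 1.1-fold higher number from compound 1 to compound 2 (0.03 log units; within the scatter) and so left the number unmoved. For the measured compounds named here, no measured compound carries cyclohexyl, and a single step is thin ground, so the direction remains open.

No step beyond the scatter is expected in this assay on this evidence. The estimate amounts to an expected 1.2-fold lower number from compound 2 to compound 3 (0.09 log units; within the scatter) as a working figure. In this assay compound 3 is expected at 11000 nM within an estimated range of 4500 nM to 25000 nM for now.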

Compound 3, half-maximal effective concentration: 9500 nM
Beside the measured number, compound 3's estimate is 1.2-fold (0.06 log units) above it; the range from low to high includes it.
By their numbers in this assay, from the lowest: compounds 3, 1 and 2 (each within the scatter of the next).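

On an aromatic carbon para to a large group, the series now holds three different groups, and in this assay cyclohexyl gives a 1.4-fold lower number from compound 2 to compound 3 (0.15 log units; within the scatter) and a 1.3-fold lower number from compound 1 to compound 3 (0.12 log units; within the scatter). Going from 1H-imidazol-1-yl, a five-membered aromatic ring with hydrogen-bond acceptors, to cyclohexyl, a six-membered non-aromatic ring of carbon only with none, thus leaves the read-out within the scatter, so across these three compounds neither an aromatic ring nor a hydrogen-bond acceptor in this group is required for a number of this order. No measurement is available here that would account for this flat result.

As far as these compounds go, whether the position stays equally flat with a group of another kind, such as an amine, a carboxylic acid or a longer carbon chain, remains open. All three compounds share the rest of the core, so they cannot show what changes elsewhere on it would do to the number, or whether a change there would make this position matter.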